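The compounds below may be only part of what the source reports. "The series", "measured", "known", "first", "only" and "open" are said of these compounds alone.

Measured compounds:
- Compound 1 `O=C(/C=C/c1ccc(OCc2cn(Cc3ccccc3Br)nn2)cc1)c1ccc(Br)cc1` gives 44% in a functional assay on MCF7 cells (Homo sapiens) for inhibition, read by MTT assay, with a stated time of 48 h, tested at 10 uM; a lower number here means less inhibition of growth, a higher number more inhibition of growth at the concentration tested.
- Compound 2 `O=C(/C=C/c1ccc(OCc2cn(Cc3ccc(Br)cc3)nn2)cc1)c1ccc(Br)cc1` gives 23% in this assay.

Compound 2 stands lowest of the two numbers in this assay; its nearest neighbour is compound 1, and the step of a number 21 percentage points lower from compound 1 to compound 2 (beyond the scatter) lies beyond the scatter. That step concerns the bromophenyl group on the saturated chain carbon bound to the aromatic nitrogen, not the carbonyl-bearing ring.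

Compound 3 `O=C(/C=C/c1ccc(OCc2cn(Cc3ccc(Br)cc3)nn2)cc1)c1ccc([N+](=O)[O-])cc1` has not yet been measured. It differs from compound 2 by nitro in place of bromo on an aromatic carbon. Among the measured compounds shown here, no measured step touches this part of the shared core, so the one known step gives no direct guide to the size or direction of the change. With nothing to show otherwise, the expectation for compound 3 in this assay is a step of a number 4 percentage points higher from compound 2 to compound 3 (within the scatter), that is, no change beyond the scatter from compound 2 is expected. Compound 3 is therefore estimated at 27%, with a range from 8% to 52%.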

Compound 3, percent growth inhibition at one concentration: 18%
Compound 3: middle estimate off by 9 percentage points, on the high side; low and high end bracket the measured number.
By their numbers in this assay, from the lowest: compounds 3 and 2 (each within the scatter of the next); then compound 1.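

In this assay, among the compounds shown here, the exchange of 4-bromophenyl for 4-nitrophenyl on the carbonyl gives a number 5 percentage points lower from compound 2 to compound 3 (within the scatter), the first measured step at this position, and it leaves the two compounds within the scatter of each other. Although this change replaces a single bromine with a nitro group that brings three heavy atoms and two hydrogen-bond acceptors, here it does not produce a step as large as a number 21 percentage points lower from compound 1 to compound 2 (beyond the scatter), which concerns the bromine on the other bromophenyl group and lies beyond the scatter. No measured evidence bears on the reason for this contrast between the two steps.

The compounds shown leave open whether the exchange of bromo for nitro would give a similar result alongside the 2-bromophenyl group of compound 1, since the step at this position is known only alongside the 4-bromophenyl group. They also leave open how groups of another kind on this aromatic carbon, such as an amine, a carboxylic acid or a methoxy group, would read in this assay.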